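Chloro on the Phenyl Ring, Tested on Two Cores

This account rests on a few compounds, and the source may have more. Where it says the series, first, only, none or still open, it means among the compounds named here.

Compound 1, `N#Cc1c(-c2ccccc2)nc(SCC(=O)Nn2c(COc3ccc(Cl)cc3Cl)nc3ccccc3c2=O)n(Cc2ccccc2)c1=O`: 79%
Compound 2, `N#Cc1c(-c2ccc(Cl)cc2)nc(SCC(=O)Nn2c(COc3ccc(Cl)cc3Cl)nc3ccccc3c2=O)n(Cc2ccccc2)c1=O`: 77.2%
Compound 3, `N#Cc1c(Cl)nc(SCC(=O)Nn2c(COc3ccc(Cl)cc3Cl)nc3ccccc3c2=O)nc1-c1ccccc1`: 66.7%

All three were measured in a functional assay on the whole organism (strain albino) for inhibition, with Rattus norvegicus as the target, read by paw edema, with stated times of 1 h and 2 h, at a dose of 100 mg/kg by the oral route; a higher number here means more inhibition at the dose given (going by the name of the read-out), a lower number less inhibition. Compound 1 and compound 2 share one core and differ only by chloro in place of hydrogen on an aromatic carbon; that change gave a number 1.8 percentage points lower from compound 1 to compound 2 (within the scatter). Compound 3 has a different core; how the two cores differ is not broken down here. Compound 4, `N#Cc1c(Cl)nc(SCC(=O)Nn2c(COc3ccc(Cl)cc3Cl)nc3ccccc3c2=O)nc1-c1ccc(Cl)cc1`, is compound 3 altered by chloro in place of hydrogen on an aromatic carbon, the same change seen between compound 1 and compound 2.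

Because the earlier step was a number 1.8 percentage points lower from compound 1 to compound 2 (within the scatter), the step of a number 1.7 percentage points lower from compound 3 to compound 4 (within the scatter) is expected to be small as well. On that basis compound 4 is estimated to give 65% in this assay, with a likely range from 55% to 75%.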

Compound 4, a percentage reported as inhibition, in the whole organism at one dose (the size of the read-out at that dose, not a potency): 68.4%
For compound 4 the middle estimate is 3.4 percentage points below the measured one, and the stated range covers the measured number.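

On the core of compound 3, the change from phenyl to 4-chlorophenyl gave a number 1.7 percentage points higher from compound 3 to compound 4 (within the scatter) in this assay. Set beside the same change on the other core, the step carries over as a small one on both: the same change on two cores in this assay, a number 1.8 percentage points lower (within the scatter) from compound 1 to compound 2 and a number 1.7 percentage points higher (within the scatter) from compound 3 to compound 4, 3.5 percentage points apart, within the scatter of two such steps. This rests on just two pairs at a single dose, so it shows that the change stayed within the scatter on these two cores, but not that it would do so on any other core.

The compounds shown leave open whether a different group in the same place, such as an amine or a carboxylic acid, would give a step beyond the scatter. On these data alone, how chloro would behave at other places on that ring also remains open.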